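The source may hold more compounds than are shown below. What is called first, only, known or untested is meant among the compounds shown, and "the series" means these compounds.

Measured compounds:
compound 1, `COc1cc2nc(N3CCN(C(=O)CCc4ccccc4)CC3)nc(N)c2cc1OC`, 3.39 nM
compound 2, `COc1cc2nc(N3CCN(C(=O)c4ccc5ccccc5c4)CC3)nc(N)c2cc1OC`, 49 nM

Among the measured compounds shown here, in an assay for binding affinity to Adrenergic receptor alpha-1 (Rattus norvegicus) (a higher number here means a weaker inhibitor, a lower number a stronger inhibitor), compound 2 stands at the highest of the two numbers known here; its only neighbour is compound 1, and the step from that compound was a 14-fold higher number from compound 1 to compound 2 (1.16 log units; beyond the scatter). Compound 3, `COc1cc2nc(N3CCN(C(=O)Nc4ccccc4)CC3)nc(N)c2cc1OC`, is the next compound to be measured; the change from compound 2 is anilino in place of naphthalen-2-yl on a carbonyl carbon. For the measured compounds named here, the one measured step that bears on this position is a 14-fold higher number from compound 1 to compound 2 (1.16 log units; beyond the scatter), a large rise when naphthalen-2-yl replaced phenethyl on the same carbonyl carbon. Anilino brings back a single six-membered aromatic ring of carbon, as phenethyl in compound 1 has, and drops the second fused ring of naphthalen-2-yl. The account therefore expects a fall in this assay for compound 3, of about a 4.1-fold lower number from compound 2 to compound 3 (0.61 log units; beyond the scatter), though not necessarily the whole way back to compound 1. The estimate for compound 3 is 12 nM, with a range from 3 nM to 45 nM.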

Compound 3, half-maximal inhibitory concentration: 27.5 nM
Compound 3: middle estimate off by 2.3-fold (0.36 log units), on the low side; the measured number falls inside the stated range.
By their numbers in this assay, from the lowest: compound 1; then compounds 3 and 2 (each within the scatter of the next).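

In this assay, returning to a single aromatic ring does not by itself bring back the low number of compound 1: anilino in place of naphthalen-2-yl on the carbonyl carbon gives a 1.8-fold lower number from compound 2 to compound 3 (0.25 log units; within the scatter) and so leaves the two compounds level within the usual scatter. Set against phenethyl, the same anilino group gives an 8.1-fold higher number from compound 1 to compound 3 (0.91 log units; beyond the scatter). Among these three compounds, then, removing the second fused ring is not enough to match compound 1, and phenethyl alone stands apart at this position. Nothing available here explains that difference.

As far as these compounds go, what benzyl or a longer chain such as 3-phenylpropyl would give on the same carbonyl carbon remains open. So does whether a chlorine on the ring of anilino would move the number in this assay.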